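Fluorine on a Distal Phenyl in Two Indole Series

The source may hold more compounds than are shown below. What is called first, only, known or untested is meant among the compounds shown, and "the series" means these compounds.

Measured compounds:
Compound 1 `COc1ccc(-c2cc3cc(-c4ccccc4)cc(C(C)=O)c3[nH]2)cc1`: 18900 nM
Compound 2 `COc1ccc(-c2cc3cc(-c4ccc(F)cc4)cc(C(C)=O)c3[nH]2)cc1`: 42800 nM
Compound 3 `CC(=O)c1cc(/C=C/c2ccccc2)cc2cc(-c3ccccc3)[nH]c12`: 30800 nM

In a functional assay on HeLa cells (Homo sapiens) for cytotoxicity, read by MTT assay, with a stated time of 2 days (on this read-out higher numbers stand for lower toxicity in this test and lower numbers for higher toxicity in this test), compound 1 gives 18900 nM and compound 2 gives 42800 nM. The change between them is fluoro in place of hydrogen on an aromatic carbon, and it produced a 2.3-fold higher number from compound 1 to compound 2 (0.35 log units; beyond the scatter). The core of compound 3 differs from that of compound 1 in a way not broken down here. In this assay compound 3 gives 30800 nM; its value and those of compounds 1 and 2 lie within the scatter of one another. Compound 4 `CC(=O)c1cc(/C=C/c2ccc(F)cc2)cc2cc(-c3ccccc3)[nH]c12` is not yet measured; it differs from compound 3 by fluoro in place of hydrogen on an aromatic carbon, the same change as from compound 1 to compound 2, at a place described in the same words. Because a 2.3-fold higher number from compound 1 to compound 2 (0.35 log units; beyond the scatter) was modest, a similar step is expected here. Compound 4 is therefore estimated at 55000 nM, between 20000 nM and 130000 nM, which corresponds to a 1.8-fold higher number from compound 3 to compound 4 (0.25 log units; within the scatter).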

Compound 4, concentration lethal to 50% of the cells: 9260 nM
Compound 4: middle estimate off by 5.9-fold (0.77 log units), on the high side; the measured number lies below the stated range.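

In this assay, fluoro in place of hydrogen on an aromatic carbon gave a 3.3-fold lower number from compound 3 to compound 4 (0.52 log units; beyond the scatter), which runs the opposite way to the step seen on the core of compound 1, and the two steps clearly differ: the same change on two cores in this assay, a 2.3-fold higher number (0.35 log units; beyond the scatter) from compound 1 to compound 2 and a 3.3-fold lower number (0.52 log units; beyond the scatter) from compound 3 to compound 4, 7.5-fold (0.88 log units) apart, beyond the scatter of two such steps This shows that, for these two pairs, neither the size nor the direction of the change carried from one core to the other. It does not show why they diverge, since the pairs differ in their cores and the fluorine sits on a phenyl in one pair and on a 2-phenylethenyl in the other, and two pairs give no rule for further cores.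

From the compounds shown here alone, whether chloro or an amine in place of the same hydrogen would also split between the two cores remains open. So does the direction of the fluoro step on any other core.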